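Morpholine in Place of Methoxyphenyl on the Amide Nitrogen

The source may hold more compounds than are shown below. What is called first, only, known or untested is meant among the compounds shown, and "the series" means these compounds.

Compound 1 `COc1ccc(/C=C/C(=O)OCC(=O)Nc2ccc(Cl)cc2)cc1OC`: 31900 nM
Compound 2 `O=C(COC(=O)/C=C/c1ccc(O)c(O)c1)Nc1ccc(Cl)cc1`: 8100 nM
Compound 3 `COc1ccc(NC(=O)COC(=O)/C=C/c2ccc(O)c(O)c2)cc1`: 72100 nM

In a functional assay on HL-60 cells (Homo sapiens) for cytotoxicity, read by MTT assay, with a stated time of 72 h (a lower number here means a stronger inhibitor, a higher number a weaker inhibitor), compound 3 gives 72100 nM, the highest number of the three. Its nearest neighbour is compound 1, which gives 31900 nM, and the gap between the two lies beyond the scatter. For the measured compounds named here, the only single-change step available is an 8.9-fold higher number from compound 2 to compound 3 (0.95 log units; beyond the scatter), which alters a group on the aromatic ring attached to the amide nitrogen and shows that this ring is sensitive to what it carries.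

Compound 4 `O=C(COC(=O)/C=C/c1ccc(O)c(O)c1)NN1CCOCC1` goes further: morpholin-4-yl in place of 4-methoxyphenyl on an amide-type nitrogen. Going by the values given here, no measured step removes the aromatic ring itself, so the measured data give only indirect guidance; the one step that touches this part of the molecule shifted the number in a modest way. Given that compound 3 already gives 72100 nM and that the ring it keeps has proved sensitive, compound 4 is estimated at 100000 nM (range 30000 nM to 300000 nM), a step of a 1.4-fold higher number from compound 3 to compound 4 (0.14 log units; within the scatter) that is expected to be towards a higher number, with wide uncertainty.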

Compound 4, half-maximal inhibitory concentration: > 200000 nM
Compound 4: a limit, no number; the forecaster's own chance of this, stated with the estimate: 25%; middle value at least 2.0-fold (0.30 log units) away from the limit.
By their numbers in this assay, from the lowest: compound 2; then compound 1; then compound 3. At a limit, above all of these: compound 4.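

In this assay compound 4 reads > 200000 nM, which is a limit and not a number: the limit of > 200000 nM in this assay, at which 1 of the 4 values shown sits. The earlier step only exchanged the group carried by the aromatic ring, whereas this change replaces the ring itself, giving an at least 2.7-fold higher number from compound 3 to compound 4 (0.44 log units; beyond the scatter) and an at least 24-fold higher number from compound 2 to compound 4 (1.39 log units; beyond the scatter). Both steps lie beyond the scatter, so the group on the amide-type nitrogen can shift the reading through the ring as a whole, not only through what that ring carries.

With a single non-aromatic ring at this place, the compounds shown cannot separate the loss of the aromatic ring from something particular to morpholin-4-yl. As far as these compounds go, a cyclohexyl group on this nitrogen would bear on that question, and how far the true value of compound 4 lies past its limit stays unknown.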